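Aryl amide variation on the shared core

The source may report more compounds than this note shows. Statements on the series, on what has been measured and on what is new or still open speak of the compounds shown alone.

Compound 2 `CC(=O)c1ccc(NC(=O)/C=C/C(=O)N2C/C(=C\c3ccccc3)C(=O)/C(=C/c3ccccc3)C2)cc1` is measured in a functional assay on L1210 cells (Mus musculus) for cytotoxicity (a higher number here means a weaker inhibitor, a lower number a stronger inhibitor), at 5500 nM. Compound 1 `O=C(/C=C/C(=O)N1C/C(=C\c2ccccc2)C(=O)/C(=C/c2ccccc2)C1)Nc1ccccc1` gives 3600 nM in this assay, and compound 3 `O=C(/C=C/C(=O)N1C/C(=C\c2ccc([N+](=O)[O-])cc2)C(=O)/C(=C/c2ccc([N+](=O)[O-])cc2)C1)Nc1ccc([N+](=O)[O-])cc1`, which carries nitro substituents on each aryl group, gives 1000 nM. On these numbers compound 2 stands highest, but the step of a 1.5-fold higher number from compound 1 to compound 2 (0.18 log units; within the scatter) lies within the scatter, so compound 1 and compound 2 cannot be ordered, while the gap from compound 2 to compound 3 lies beyond it.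

Compound 4 `Cc1cccc(C)c1NC(=O)/C=C/C(=O)N1C/C(=C\c2ccccc2)C(=O)/C(=C/c2ccccc2)C1` differs from compound 2 by 2,6-dimethylphenyl in place of 4-acetylphenyl on an amide-type nitrogen. For the measured compounds named here, the only measured step that touches the aryl amide terminus is a 1.5-fold higher number from compound 1 to compound 2 (0.18 log units; within the scatter), which left the number essentially where it was. Going by the values given here, no measured pair shows methyl substitution on this ring, and no pair changes the aryl amide group alone in any other way; compound 3 changes every aryl group at once, so its value of 1000 nM cannot be attributed to the amide end. The expectation is therefore a step of a 1.2-fold lower number from compound 2 to compound 4 (0.09 log units; within the scatter) that stays within the scatter. Compound 4 is expected to give 4500 nM in this assay, with a range from 1500 nM to 12000 nM.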

Compound 4, half-maximal inhibitory concentration: 22000 nM
The estimate for compound 4 lay 4.9-fold (0.69 log units) below the measured number, and the stated range ends below it.
By their numbers in this assay, from the lowest: compound 3; then compounds 1 and 2 (each within the scatter of the next); then compound 4.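

Notes on the aryl amide terminus: the group on the amide-type nitrogen is not indifferent to change, since in this assay both a 4.0-fold higher number from compound 2 to compound 4 (0.60 log units; beyond the scatter) and a 6.1-fold higher number from compound 1 to compound 4 (0.79 log units; beyond the scatter) lie beyond the scatter, whereas a 1.5-fold higher number from compound 1 to compound 2 (0.18 log units; within the scatter) lies within it. Both steps run toward a weaker inhibitor, so 2,6-dimethylphenyl reads the same way against phenyl and against 4-acetylphenyl, although this rests on these two pairs alone and the steps are modest in size. No measurement available here accounts for this shift.

Open, going by these compounds, is whether the shift needs both methyl groups, as a ring with a single methyl, or with an ethyl group or a chlorine, would help to separate the effect of one substituent from that of the pair. Also open, on these data alone, is what a nitro group does on the amide ring alone, as compound 3 changes every aryl group at once, and whether an amine or a carboxylic acid on this ring would move the number in either direction.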